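The source may report more compounds than this note shows. Statements on the series, on what has been measured and on what is new or still open speak of the compounds shown alone.

Two compounds with a shared core carry the same ring-bound methyl side chain and differ only in the group hanging from the chain. Compound 2 `CN1CCC[C@@H]1Cn1nc(Cc2ccc(O)cc2)c2ccccc2c1=O` carries a 4-hydroxyphenyl there; compound 1 `O=c1c2ccccc2c(Cc2ccc(Cl)cc2)nn1CCNCCCCc1ccc(OCCCN2CCCCCC2)cc1` carries a longer, more branched side chain. In an assay for binding affinity to Alpha-1A adrenergic receptor (Homo sapiens) (on this read-out lower numbers stand for stronger inhibition and higher numbers for weaker inhibition), compound 2 gives 251 nM and compound 1 gives 316 nM; these two numbers lie within the usual scatter of each other, so neither compound can be called the stronger binder on this evidence.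

Compound 3 `CN1CCC[C@@H]1Cn1nc(CC2CCCCC2)c2ccccc2c1=O` has not been measured. It follows from compound 2 by one change: cyclohexyl in place of 4-hydroxyphenyl on a saturated chain carbon bound to an aromatic carbon. Among the measured compounds shown here, no measured pair shows this exact swap, so its effect is an expectation only. Removing the one hydrogen-bond donor and the one acceptor is expected to cost some binding, a step from compound 2 to compound 3 of a 2.5-fold higher number from compound 2 to compound 3 (0.40 log units; beyond the scatter) in this assay. For compound 3 the expected value in this assay is therefore 630 nM, with a likely range from 200 nM to 2500 nM.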

Compound 3, inhibition constant: > 1990 nM
Compound 3: no number, only a limit (the forecaster's own chance of this, stated with the estimate: 5%); at least 3.1-fold (0.49 log units) between middle value and limit.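

This is the only step shown that changes a single place: on a saturated chain carbon bound to an aromatic carbon, cyclohexyl in place of 4-hydroxyphenyl gives an at least 7.9-fold higher number from compound 2 to compound 3 (0.89 log units; beyond the scatter) in this assay. The group at this position therefore matters for binding here, and a non-aromatic carbon ring does not stand in for the 4-hydroxyphenyl. The full size of the step stays unknown, and compound 3 has only a limit of the assay, not a number: the limit of > 1990 nM in this assay, at which 1 of the 3 values shown sits.

The change removes the aromatic ring and the hydroxyl together, so the compounds shown cannot tell which of the two counts. An unsubstituted phenyl or a 4-methoxyphenyl on the same chain carbon would separate these two parts of the change.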